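A Halogen Swap Tested Twice in One Series

A few compounds are considered here, and "the series" means these few. Any claim that something is new, unique, unknown or untested is made for them only; others in the source may bear on it.

Compound 3 `C=CC(=O)Nc1cccc(NC(=O)CSc2nc(Nc3ccc(F)cc3)c3ccccc3n2)c1` and compound 2 `O=C(CSc1nc(Nc2ccccc2)c2ccccc2n1)Nc1ccc(F)c(Cl)c1` differ in more than one place, so the difference between the two cores is not broken down here. In a functional assay on NCI-H1975 cells (Homo sapiens) for inhibition, read by MTT assay, with a stated time of 72 h (on this read-out lower numbers stand for stronger inhibition and higher numbers for weaker inhibition), compound 2 gives 9390 nM, and compound 3 gives 4430 nM. Compound 1 `O=C(CSc1nc(Nc2ccccc2)c2ccccc2n1)Nc1ccc(Cl)c(Cl)c1` gives 10400 nM. The change from compound 2 to compound 1 is chloro in place of fluoro on an aromatic carbon and it produced a 1.1-fold higher number from compound 2 to compound 1 (0.04 log units; within the scatter). Compound 4 `C=CC(=O)Nc1cccc(NC(=O)CSc2nc(Nc3ccc(Cl)cc3)c3ccccc3n2)c1` arises from compound 3 by the same kind of change, (chloro in place of fluoro on an aromatic carbon); the surroundings differ, since in the earlier pair the changed carbon was also ortho to a chloro group. The expectation for compound 4 rests on compound 3 at 4430 nM and on the earlier step of a 1.1-fold higher number from compound 2 to compound 1 (0.04 log units; within the scatter), which stayed within the scatter. Compound 4 is therefore expected to give 5000 nM, between 2500 nM and 10000 nM. That estimate means an expected step of a 1.1-fold higher number from compound 3 to compound 4 (0.05 log units; within the scatter).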

Compound 4, half-maximal inhibitory concentration: 7580 nM
Compound 4: the middle estimate sits 1.5-fold (0.18 log units) below what was measured; the range from low to high includes it.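

In this assay, chloro in place of fluoro gave a 1.7-fold higher number from compound 3 to compound 4 (0.23 log units; within the scatter), a step too small to count as a real change. The same swap on the other core behaved alike, and the two steps cannot be told apart: the same change on two cores in this assay, a 1.1-fold higher number (0.04 log units; within the scatter) from compound 2 to compound 1 and a 1.7-fold higher number (0.23 log units; within the scatter) from compound 3 to compound 4, 1.5-fold (0.19 log units) apart, within the scatter of two such steps. This shows that in these two pairs the swap left the number about where it was on either core, but it does not show that the two cores respond identically, and two pairs do not make a rule for the series.

Still open, from the compounds shown here alone, is whether a different group in the same place, such as bromo, methoxy or an amine, would give a step beyond the scatter on either core.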